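A few compounds are considered here, and "the series" means these few. Any claim that something is new, unique, unknown or untested is made for them only; others in the source may bear on it.

Measured so far:
- compound 1, `CS(=O)(=O)Nc1ccc(Cl)c2c1CCCC2c1c[nH]cn1`: 41% in a functional assay on Urethra with Alpha-1A adrenergic receptor (Oryctolagus cuniculus) as the target; a higher number here means a larger maximal response, a lower number a smaller maximal response
- compound 2, `CS(=O)(=O)Nc1cccc2c1OCCC2c1c[nH]cn1`: 88% in this assay

Compound 1 stands lowest of the two numbers; the nearest neighbour is compound 2, whose maximal response lies higher by a margin beyond the scatter. Within the data shown here, no step between two measured compounds differing in a single place is available, so nothing yet shows how a change at one position moves the maximal response in this assay.

Compound 3, `Cc1ccc(NS(C)(=O)=O)c2c1C(c1c[nH]cn1)CCC2`, differs from compound 1 in one place: methyl in place of chloro on an aromatic carbon.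

Among the measured compounds shown here, with no comparable step to lean on, the size of the change from compound 1 to compound 3 is uncertain; the expected step of a number 9 percentage points higher from compound 1 to compound 3 (within the scatter) in this assay is small and not clearly beyond the scatter, with a slight lean upward. On that basis compound 3 is estimated at 50% in this assay, in a range from 25% to 80%.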

Compound 3, largest response reached (reported as efficacy), in percent of the reference or control that the assay uses: 35%
The estimate for compound 3 lay 15 percentage points above the measured number, within the range that was stated.
By their numbers in this assay, from the lowest: compounds 3 and 1 (each within the scatter of the next); then compound 2.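

Methyl in place of chloro on an aromatic carbon, para to a methanesulfonamido group, gives the first single-place step in the series, and it reads as a number 6 percentage points lower from compound 1 to compound 3 (within the scatter) in this assay on the shared core. The maximal response therefore does not tell these two groups apart at this position, and chlorine is not required there for a response at this level, at least when methyl replaces it. Nothing shown bears on why the two groups read alike.

Still open, on these data alone, is whether any group at this position moves the maximal response beyond the scatter; a bare hydrogen, a methoxy group, an amine, a carboxylic acid or a longer chain such as propyl would test this. One step also leaves open whether the same exchange reads alike on another core.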